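The source may report more compounds than this note shows. Statements on the series, on what has been measured and on what is new or still open speak of the compounds shown alone.

In a functional assay on MCF7 cells (Homo sapiens) for cytotoxicity (a lower number here means a stronger inhibitor, a higher number a weaker inhibitor), compound 1 `Nc1ccc(-c2nc3cc(O)ccc3s2)cc1` reaches only a limit of the assay, > 100000 nM. Compound 2 `Nc1ccc(-c2nc3cc(O)ccc3s2)cc1Cl` gives a real number, 60600 nM, and its nearest neighbour, compound 3 `CC(=O)Nc1ccc(-c2nc3cc(O)ccc3s2)cc1Cl`, gives 31000 nM, so the two lie within the scatter of each other. Compound 4 `Cc1cc(-c2nc3cc(O)ccc3s2)ccc1N` has methyl in place of chloro on an aromatic carbon, ortho to an amino group (methyl in place of chloro on an aromatic carbon).

Going by the values given here, no measured pair compares these two groups directly, so the nearest evidence comes from two other changes. Putting chloro in place of hydrogen on an aromatic carbon gave an at least 1.6-fold lower number from compound 1 to compound 2 (0.21 log units; that floor lies within the scatter), though that figure is only a floor. Acetyl in place of hydrogen on a nitrogen on an aromatic ring gave a 2.0-fold lower number from compound 2 to compound 3 (0.29 log units; within the scatter). Neither step shows a change beyond the scatter, so a large move from this swap would be a surprise.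

The expected change is small, a 1.2-fold higher number from compound 2 to compound 4 (0.06 log units; within the scatter), with no shift beyond the scatter in this assay. For compound 4 the estimated value is 70000 nM, with an expected range from 30000 nM to 100000 nM.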

Compound 4, half-maximal inhibitory concentration: 78700 nM
Compound 4: the middle estimate sits 1.1-fold (0.05 log units) below what was measured; low and high end bracket the measured number.
By their numbers in this assay, from the lowest: compounds 3, 2 and 4 (each within the scatter of the next, the first and the last beyond it). At a limit, above all of these: compound 1.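

On this aromatic carbon, ortho to an amino group, chloro and methyl can now be compared directly, and in this assay the swap gives a 1.3-fold higher number from compound 2 to compound 4 (0.11 log units; within the scatter). Methyl in place of hydrogen at the same carbon gives an at least 1.2-fold lower number from compound 1 to compound 4 (0.10 log units; that floor lies within the scatter). That step is only a floor, and the true size of the steps from compound 1 to either substituted compound stays unknown because compound 1 stands at a limit: the limit of > 100000 nM in this assay, at which 1 of the 4 values shown sits.

Besides hydrogen, chloro and methyl are the only groups shown at this position, so what a methoxy group, a carboxylic acid or a longer chain would do there remains open. Going by these compounds, it is also open whether acetyl on the nitrogen, seen with chloro in compound 3, would give a similar step alongside the methyl of compound 4.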